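The source may hold more compounds than are shown below. What is called first, only, known or untested is meant among the compounds shown, and "the series" means these compounds.

In a functional assay on PANC-1 cells (Homo sapiens) for antiproliferative activity, read by CCK-8 assay, with a stated time of 72 h (on this read-out higher numbers stand for weaker inhibition and lower numbers for stronger inhibition), compound 2 `Cc1cc(Nc2cc(N3CCN(C)CC3)nc(Nc3cccc(Cl)c3)n2)n[nH]1` gives 351 nM and stands lowest of the two measured numbers, while compound 1 `Cc1cc(Nc2cc(N3CCN(C)CC3)nc(Nc3ccc(S(N)(=O)=O)cc3)n2)n[nH]1` gives 8760 nM in the same test. Compound 3 `COc1ccc(Nc2nc(Nc3cc(C)[nH]n3)cc(N3CCN(C)CC3)n2)cc1` carries 4-methoxyphenyl in place of 3-chlorophenyl on a nitrogen on an aromatic ring, a change counted as 4-methoxyphenyl in place of 3-chlorophenyl on a nitrogen on an aromatic ring on the shared core. Among the compounds with values here, one measured step bears on that place: a 25-fold lower number from compound 1 to compound 2 (1.40 log units; beyond the scatter) with 3-chlorophenyl in place of 4-sulfamoylphenyl on the same nitrogen. Within the data shown here, that step shows the number can move strongly with the group there, yet no measured compound carries 4-methoxyphenyl. The expected change is a 2.6-fold higher number from compound 2 to compound 3 (0.41 log units; beyond the scatter) and is estimated to fall well short of the measured step. For compound 3 the estimate is 900 nM with an expected range of 250 nM to 3500 nM in this assay here.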

Compound 3, half-maximal inhibitory concentration: 1120 nM
Beside the measured number, compound 3's estimate is 1.2-fold (0.09 log units) below it; measured number inside the range.
By their numbers in this assay, from the lowest: compound 2; then compound 3; then compound 1.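

In this assay, 4-methoxyphenyl in place of 3-chlorophenyl on the nitrogen gives a 3.2-fold higher number from compound 2 to compound 3 (0.50 log units; beyond the scatter) and so does not match the lowest number of the three, yet the same position also gives a 7.8-fold lower number from compound 1 to compound 3 (0.89 log units; beyond the scatter) when methoxy takes the place of sulfamoyl on an aromatic carbon. Compound 3 therefore falls between compound 2 and compound 1, which shows that this position yields an intermediate result as well as the two ends seen earlier. The methoxy-for-sulfamoyl step also shows that the number moves with the group on the aromatic carbon while the phenyl ring stays in place.

Going by these compounds, how far the result depends on the group itself rather than its place on the ring stays open, a question that 4-chlorophenyl or 3-methoxyphenyl would address. Nothing available explains why these numbers differ.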